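Pyridin-4-yl in Place of Pyridin-3-yl: A Small Expected Step

This account rests on a few compounds, and the source may have more. Where it says the series, first, only, none or still open, it means among the compounds named here.

Of the compounds shown here, three sharing one core have been measured in a functional assay on HCT-15 cells (Homo sapiens) for cytotoxicity, read by ELISA, with a stated time of 2 days; on this read-out lower numbers stand for stronger inhibition and higher numbers for weaker inhibition. Compound 1 `Oc1cccc(-c2cc(-c3ccccc3)nc(-c3ccsc3)c2)c1` gives 24600 nM, compound 2 `Oc1cccc(-c2cc(-c3ccccc3)nc(-c3ccco3)c2)c1` gives 13900 nM, and compound 3 `Oc1cccc(-c2cc(-c3ccccc3)nc(-c3cccnc3)c2)c1` gives 18400 nM. These three values all lie within the scatter of one another, so compound 3 stands level with the others. Compound 4 `Oc1cccc(-c2cc(-c3ccccc3)nc(-c3ccncc3)c2)c1` carries pyridin-4-yl in place of pyridin-3-yl on an aromatic carbon. The closest evidence comes from swaps of the group at this same place: a 1.8-fold lower number from compound 1 to compound 2 (0.25 log units; within the scatter), a 1.3-fold lower number from compound 1 to compound 3 (0.13 log units; within the scatter) and a 1.3-fold higher number from compound 2 to compound 3 (0.12 log units; within the scatter). All stayed within the scatter, so no real change is expected in this assay. The expected step is a 1.1-fold lower number from compound 3 to compound 4 (0.03 log units; within the scatter). For compound 4 the estimated value is 17000 nM, with an expected range from 8000 nM to 36000 nM.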

Compound 4, half-maximal inhibitory concentration: 18700 nM
Beside the measured number, compound 4's estimate is 1.1-fold (0.04 log units) below it; the measured number falls inside the stated range.
By their numbers in this assay, from the lowest: compounds 2, 3, 4 and 1 (each within the scatter of the next).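

Pyridin-4-yl and pyridin-3-yl, the same atoms joined differently, stand level in this assay (a 1.0-fold higher number from compound 3 to compound 4 (0.01 log units; within the scatter)), so shifting the pyridine attachment at this place makes no readable difference. Pyridin-4-yl also stands level with furan-2-yl (a 1.3-fold higher number from compound 2 to compound 4 (0.13 log units; within the scatter)) and with thiophen-3-yl (a 1.3-fold lower number from compound 1 to compound 4 (0.12 log units; within the scatter)), so all four aromatic rings shown here sit within the scatter of one another. No measurement at hand explains this flat picture.

Going by these compounds, all four compounds carry an aromatic ring at this place, so it remains open whether an amine or a carboxylic acid there would give a different number.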